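Hydroxy in place of fluoro: a sulfonamide series

A few compounds are considered here, and "the series" means these few. Any claim that something is new, unique, unknown or untested is made for them only; others in the source may bear on it.

compound 1 `COc1cc(/C=C/c2ccc(S(N)(=O)=O)cc2)cc(OC)c1` gives 19700 nM
compound 2 `NS(=O)(=O)c1ccc(/C=C/c2ccc(O)c(O)c2)cc1` gives 12700 nM
compound 3 `NS(=O)(=O)c1ccc(/C=C/c2ccc(F)cc2)cc1` gives 10500 nM

All three values come from a functional assay on SR cells (Homo sapiens) for inhibition (on this read-out higher numbers stand for weaker inhibition of growth and lower numbers for stronger inhibition of growth), and lie within the scatter of one another. Compound 3 therefore stands level with compound 2 and compound 1 on these numbers, and the measured set supports no ranking.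

The next structure is compound 4 `NS(=O)(=O)c1ccc(/C=C/c2ccc(O)cc2)cc1` which carries hydroxy in place of fluoro on an aromatic carbon, para to a large group (hydroxy in place of fluoro on an aromatic carbon). Among the compounds with values here, no pair of measured compounds differs in one place only, so this change has no direct precedent here. Compound 2 also carries hydroxy groups, and its value (12700 nM) does not separate from that of compound 3.

In this assay the expected outcome is a 1.0-fold higher number from compound 3 to compound 4 (0.02 log units; within the scatter) and so nothing beyond the scatter. For compound 4 the estimated value is 11000 nM (expected range 5000 nM to 22000 nM).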

Compound 4, concentration for 50% growth inhibition: 4680 nM
The estimate for compound 4 lay 2.4-fold (0.37 log units) above the measured number, and the stated range ends above it.
By their numbers in this assay, from the lowest: compound 4; then compounds 3, 2 and 1 (each within the scatter of the next).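

In this assay, within the data shown here, hydroxy in place of fluoro on an aromatic carbon, para to a large group, gives the first one-place step that clears the scatter (a 2.2-fold lower number from compound 3 to compound 4 (0.35 log units; beyond the scatter)), though the step is modest. Hydrogen in place of hydroxy on an aromatic carbon also moves the number beyond the scatter (a 2.7-fold lower number from compound 2 to compound 4 (0.43 log units; beyond the scatter)), so compound 4, with its single hydroxy, reads lower than both its fluoro neighbour compound 3 and its dihydroxy neighbour compound 2. No measured evidence bears on the origin of either step.

As far as these compounds go, whether an amine or a carboxylic acid at this place would go lower or higher than hydroxy remains open. Also open, from the compounds shown here alone, is whether the hydroxy step holds with the sulfonamide replaced, for instance by a carboxylic acid.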